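Replacing a trifluoromethoxyphenyl with a methylphenyl on the pyridazinone

A few compounds are considered here, and "the series" means these few. Any claim that something is new, unique, unknown or untested is made for them only; others in the source may bear on it.

Of the compounds shown here, three have so far been tested in a functional assay on HepG2 cells (Homo sapiens) for cytotoxicity, read by MTT assay, with a stated time of 72 h; on this read-out higher numbers stand for weaker inhibition and lower numbers for stronger inhibition. Compound 1 `CNC(=O)c1cc(Oc2ccc(NC(=O)c3nn(-c4ccc(C)cc4)c(=O)cc3C)cc2F)ccn1` gives 10600 nM. Compound 2 `Cc1cc(=O)n(-c2ccccc2C(F)(F)F)nc1C(=O)Nc1ccc(Oc2ncnc3ccsc23)c(F)c1` gives 9380 nM. Compound 3 `Cc1cc(=O)n(-c2ccccc2OC(F)(F)F)nc1C(=O)Nc1ccc(Oc2ncnc3ccsc23)c(F)c1` gives 15700 nM. Of the three numbers that of compound 3 is the highest, yet its gaps to compound 1 and to compound 2 are both within the scatter, so the three cannot be ordered.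

The unmeasured compound 4 `Cc1ccc(-n2nc(C(=O)Nc3ccc(Oc4ncnc5ccsc45)c(F)c3)c(C)cc2=O)cc1` differs from compound 3 in one place: 4-methylphenyl in place of 2-(trifluoromethoxy)phenyl on an aromatic nitrogen. For the measured compounds named here, the only measured step at this position is a 1.7-fold higher number from compound 2 to compound 3 (0.22 log units; within the scatter), a swap between two groups on the same phenyl that left the number essentially unchanged. Compound 1 carries the same 4-methylphenyl group on its ring nitrogen, though with a different core, and its number sits in the same range as that of compound 3. Going by the values given here, nothing among the measured compounds therefore points to a shift beyond the scatter, in either direction.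

For compound 4 the step is expected to be a 1.3-fold lower number from compound 3 to compound 4 (0.12 log units; within the scatter), in this assay essentially flat. Compound 4 is estimated to give 12000 nM, within a range from 5000 nM to 28000 nM.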

Compound 4, half-maximal inhibitory concentration: 17300 nM
The estimate for compound 4 lay 1.4-fold (0.16 log units) below the measured number; low and high end bracket the measured number.
By their numbers in this assay, from the lowest: compounds 2, 1, 3 and 4 (each within the scatter of the next).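

In this assay, the step at the aromatic nitrogen is a 1.1-fold higher number from compound 3 to compound 4 (0.04 log units; within the scatter), and the exchange of the other group at that nitrogen is a 1.8-fold higher number from compound 2 to compound 4 (0.27 log units; within the scatter). On the shared core, therefore, the 4-methylphenyl group, with carbon as its only heavy atoms, cannot be told apart from either 2-(trifluoromethoxy)phenyl or 2-(trifluoromethyl)phenyl, so all three groups now form a flat set at this position. With 4-methylphenyl held constant, the change in the group on the oxygen on an aromatic ring is a 1.6-fold higher number from compound 1 to compound 4 (0.21 log units; within the scatter), which shows that this second exchange also stays within the scatter, and no measurement at hand accounts for the flatness at either place.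

The compounds shown leave open whether a phenyl carrying an amine or a carboxylic acid, or a longer alkyl chain on the aromatic nitrogen, would move the number beyond the scatter. They also leave open whether the two fluorine-bearing groups would match 4-methylphenyl on the core of compound 1, where only 4-methylphenyl is shown.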